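Benzylsulfanyl series: chloro on the benzyl ring, second pair

The source may hold more compounds than are shown below. What is called first, only, known or untested is meant among the compounds shown, and "the series" means these compounds.

Measured compounds:
Compound 1, `CC1=C(C(=O)Nc2ccc([N+](=O)[O-])cc2)C(c2ccc(Br)cc2)N=C(SCc2ccccc2)N1`, gives 29.7% in a functional assay on the whole organism (artery, strain albino) with Rattus norvegicus as the target, with a stated time of 300 min, at a dose of 10 mg/kg by the oral route; a lower number here means less inhibition, a higher number more inhibition at the dose given (going by the name of the read-out).
Compound 2, `CC1=C(C(=O)Nc2ccc([N+](=O)[O-])cc2)C(c2ccc(Br)cc2)N=C(SCc2ccccc2Cl)N1`, gives 16.9% in this assay.
Compound 3, `CC1=C(C(=O)Nc2ccc([N+](=O)[O-])cc2)C(c2cccc([N+](=O)[O-])c2)N=C(SCc2ccccc2)N1`, gives 25.6% in this assay.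

Compound 3 stands second highest of the three numbers; its nearest neighbour is compound 1, and the gap between them, a number 4.1 percentage points lower from compound 1 to compound 3 (within the scatter), lies within the scatter, as does the gap to compound 2. No order among the three can be claimed on these numbers alone.

Compound 4, `CC1=C(C(=O)Nc2ccc([N+](=O)[O-])cc2)C(c2cccc([N+](=O)[O-])c2)N=C(SCc2ccccc2Cl)N1`, differs from compound 3 in one place: chloro in place of hydrogen on an aromatic carbon. The same change has been made once before in this set, on compound 1, where it gave a number 12.8 percentage points lower from compound 1 to compound 2 (beyond the scatter), a step beyond the scatter. For the measured compounds named here, that single step is the only guide, and it points downward. Compound 4 is therefore expected to show a step of a number 11.6 percentage points lower from compound 3 to compound 4 (beyond the scatter) in this assay, a decrease of a size comparable to the earlier one. The estimate for compound 4 in this assay is 14%, with a range from 4% to 24%.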

Compound 4, a percentage reported as inhibition, in the whole organism at one dose (the size of the read-out at that dose, not a potency): 15.9%
The estimate for compound 4 lay 1.9 percentage points below the measured number, and the stated range covers the measured number.
By their numbers in this assay, from the lowest: compounds 4, 2, 3 and 1 (each within the scatter of the next, the first and the last beyond it).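

On the 3-nitrophenyl compounds the chloro change gives a number 9.7 percentage points lower from compound 3 to compound 4 (within the scatter), which taken alone does not clear the scatter, but it runs in the same direction as the step on the 4-bromophenyl compounds, and the two agree in size: the same change on two cores in this assay, a number 12.8 percentage points lower (beyond the scatter) from compound 1 to compound 2 and a number 9.7 percentage points lower (within the scatter) from compound 3 to compound 4, 3.1 percentage points apart, within the scatter of two such steps

The exchange of 4-bromophenyl for 3-nitrophenyl, now seen with 2-chlorobenzyl as well, gives a number 1 percentage points lower from compound 2 to compound 4 (within the scatter), and it too reads alike in both settings: the same change on two cores in this assay, a number 4.1 percentage points lower (within the scatter) from compound 1 to compound 3 and a number 1 percentage points lower (within the scatter) from compound 2 to compound 4, 3.1 percentage points apart, within the scatter of two such steps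

Within these four compounds, the two changes therefore show no sign of depending on each other in this assay.

As far as these compounds go, whether a methoxy group or an amine in place of the chloro would read the same remains open. These are single-dose percentages, so they leave potency along the series open too.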